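Phenyl for pyridin-2-yl on the oxazole ketone

A few compounds are considered here, and "the series" means these few. Any claim that something is new, unique, unknown or untested is made for them only; others in the source may bear on it.

This account concerns a series of long-chain ketones with a shared core. Compound 1 `CCCCCCCC/C=C\CCCCCCC(=O)c1ncc(-c2ccco2)o1` bears a furan-2-yl group, and in an assay on isolated protein for inhibition of Fatty-acid amide hydrolase 1 (Homo sapiens) (a lower number here means a stronger inhibitor, a higher number a weaker inhibitor), compound 1 gives 54 nM. Compound 2 `CCCCCCCC/C=C\CCCCCCC(=O)c1nc(-c2ccccc2)c(-c2ccccc2)o1` carries two phenyl groups on the core; in this assay compound 2 gives only a limit, > 100000 nM, as noted in the limit of > 100000 nM in this assay, at which 1 of the 3 values shown sits. Compound 3 `CCCCCCCC/C=C\CCCCCCC(=O)c1ncc(-c2ccccn2)o1` bears a pyridin-2-yl group, and in this assay compound 3 gives 18 nM, the lowest of the two numbers, with a 3.0-fold lower number from compound 1 to compound 3 (0.48 log units; beyond the scatter).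

Compound 4 `CCCCCCCC/C=C\CCCCCCC(=O)c1ncc(-c2ccccc2)o1` follows from compound 3 by phenyl in place of pyridin-2-yl on an aromatic carbon. Within the data shown here, no measured step matches this change directly; the only single-place step, from compound 1 to compound 3, was modest in size, and the change to a phenyl removes the hydrogen-bond acceptor that pyridin-2-yl brought. The expectation is therefore a modest step upward in this assay, near the edge of the scatter, a 2.5-fold higher number from compound 3 to compound 4 (0.40 log units; beyond the scatter). Compound 4 is thus estimated at 45 nM, in the range 15 nM to 150 nM.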

Compound 4, inhibition constant: 320 nM
Compound 4: middle estimate off by 7.1-fold (0.85 log units), on the low side, and the stated range ends below it.
By their numbers in this assay, from the lowest: compound 3; then compound 1; then compound 4. At a limit, above all of these: compound 2.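

Among these compounds, at this carbon next to the ring oxygen, phenyl in place of pyridin-2-yl keeps the heavy-atom count and loses the ring nitrogen, yet in this assay it gives an 18-fold higher number from compound 3 to compound 4 (1.25 log units; beyond the scatter), far larger than the one earlier step. Phenyl also falls behind furan-2-yl, with a 5.9-fold higher number from compound 1 to compound 4 (0.77 log units; beyond the scatter), so the three groups at this carbon run pyridin-2-yl, furan-2-yl, phenyl, from the lowest number to the highest. Hydrogen in place of the second phenyl group gives an at least 310-fold lower number from compound 2 to compound 4 (2.49 log units; beyond the scatter), a step that rests on a value that is only a limit for compound 2: the limit of > 100000 nM in this assay, at which 1 of the 4 values shown sits.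

As far as these compounds go, it remains open whether an amine or a carboxylic acid on the phenyl ring would bring the number back toward that of compound 3. From the compounds shown here alone, how a shorter chain in place of the long chain would alter these differences also remains open.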